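The source may hold more compounds than are shown below. What is called first, only, known or untested is meant among the compounds shown, and "the series" means these compounds.

In a functional assay on the whole organism (strain albino) for inhibition, with Rattus norvegicus as the target, read by paw edema, with stated times of 1 h and 4 h, at a dose of 200 mg/kg by the oral route (on this read-out higher numbers stand for more inhibition at the one dose given (going by the name of the read-out) and lower numbers for less inhibition), compound 1, with structure `COc1ccc([C@H]2CC(c3cc4ccccc4oc3=O)=NN2c2ccccc2)cc1`, gives 36.2%. Compound 2, with structure `CN(C)c1ccc([C@H]2CC(c3cc4ccccc4oc3=O)=NN2c2ccccc2)cc1`, carries a dimethylamino group where compound 1 carries a methoxy group, and in this assay compound 2 gives 40.1%. For the measured compounds named here, the only measured step, a number 3.9 percentage points higher from compound 1 to compound 2 (within the scatter), lies within the scatter, so compound 2 is not set apart from compound 1 on the numbers so far; its number is simply one of two that cannot be told apart.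

Compound 3, with structure `O=c1oc2ccccc2cc1C1=NN(c2ccccc2)[C@@H](c2ccc(O)cc2)C1`, is the next member of the series. It differs from compound 2 in one place: hydroxy in place of dimethylamino on an aromatic carbon. Going by the values given here, no measured step covers a hydroxy group at this position; the one step available exchanges two groups of a different kind and was itself within the scatter. On this basis compound 3 is expected to give 38% in this assay, with a range from 24% to 52%, which amounts to an expected step of a number 2.1 percentage points lower from compound 2 to compound 3 (within the scatter) and therefore no change beyond the scatter.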

Compound 3, a percentage reported as inhibition, in the whole organism at one dose (the size of the read-out at that dose, not a potency): 34.6%
Beside the measured number, compound 3's estimate is 3.4 percentage points above it, and the stated range covers the measured number.
By their numbers in this assay, from the lowest: compounds 3, 1 and 2 (each within the scatter of the next).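

With compound 3, this place on the aromatic ring, para to a large group, has been read with three different groups, and in this assay none of them stands apart from the others. Putting hydroxy in place of dimethylamino yields a number 5.5 percentage points lower from compound 2 to compound 3 (within the scatter) and putting hydrogen in place of the methyl on the oxygen yields a number 1.6 percentage points lower from compound 1 to compound 3 (within the scatter) so neither change registers on this read-out at the one dose given, even though the first brings in a hydrogen-bond donor that dimethylamino does not have. No evidence beyond these numbers bears on this result.

Going by these compounds, whether a primary amine, a carboxylic acid, a chlorine atom or a longer alkoxy chain at this place would move the number beyond the scatter remains open. Also open, on these data alone, is whether this place matters at all for the read-out, or whether a change elsewhere on the shared core would make a larger difference than any exchange among hydroxy, methoxy and dimethylamino.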